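This account rests on a few compounds, and the source may have more. Where it says the series, first, only, none or still open, it means among the compounds named here.

Compound 1, `O=C(CCSc1nnc(-c2ccncc2)s1)Nc1ccc(Cl)cc1`: 8210 nM.
Compound 2, `CC(Sc1nnc(-c2ccncc2)s1)C(=O)NCc1ccc(Cl)cc1`: "not determined" (no result reported).
Compound 3, `CC(Sc1nnc(-c2ccncc2)s1)C(=O)Nc1c(Cl)cccc1Cl`: > 50000 nM.

In an ADME assay on BHK-21 cells (Mesocricetus auratus) for cytotoxicity, with a stated time of 3 days (a higher number here means that more compound is tolerated, a lower number that less compound is tolerated), compound 1 gives 8210 nM. For compound 2 the entry reads "not determined" (no result reported). For compound 3 the figure > 50000 nM is a limit of this assay, not a number; it matches (the limit of > 50000 nM in this assay, at which 1 of the 3 values shown sits). Within the data shown here, compound 1 thus holds the only plain number, beside one limit and one blank entry. Compound 4, `O=C(CCSc1nnc(-c2ccncc2)s1)Nc1ccc(Cl)cc1Cl`, is the untested neighbour of compound 1: the change is chloro in place of hydrogen on an aromatic carbon, which turns 4-chlorophenyl into 2,4-dichlorophenyl. Among the measured compounds shown here, no tested pair shows this change, so there is no measured guide. In this assay the step is expected to be a 1.5-fold higher number from compound 1 to compound 4 (0.16 log units; within the scatter), small and toward more compound tolerated. Compound 4 is therefore estimated at 12000 nM, within a range from 4000 nM to 50000 nM.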

Compound 4, half-maximal cytotoxic concentration: > 50000 nM
Compound 4: only a limit was reported (the forecaster's own chance of this, stated with the estimate: 25%); middle value at least 4.1-fold (0.61 log units) away from the limit.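

In this assay, chloro in place of hydrogen on the aromatic carbon ortho to a large group gives an at least 6.0-fold higher number from compound 1 to compound 4 (0.78 log units; beyond the scatter), the only measured step among these compounds. Going from 4-chlorophenyl to 2,4-dichlorophenyl therefore moves the read-out toward more compound tolerated. The result for compound 4 is a limit and not a number, so the full size of the step stays unknown: the limit of > 50000 nM in this assay, at which 2 of the 4 values shown sit.

Still open, going by these compounds, is whether a different group at this position, such as an amine or a methoxy group, would shift the read-out in the same way.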